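Series notes: nitro in place of fluoro

The source may hold more compounds than are shown below. What is called first, only, known or untested is meant among the compounds shown, and "the series" means these compounds.

The three measured compounds share one core and differ in the groups attached to it. Compound 1 `Clc1ccccc1-c1nnc2nnc(N3CCCC3)nn12` gives 2660 nM in a functional assay on HL-60 cells (Homo sapiens) for cytotoxicity, read by MTT assay, with a stated time of 72 h; a higher number here means a weaker inhibitor, a lower number a stronger inhibitor. Compound 2 `Fc1ccc(-c2nnc3nnc(N4CCCC4)n3n2)cc1` gives 4560 nM in this assay; these two values lie within the scatter of each other, so neither compound can be placed ahead of the other. Compound 3 `Fc1ccc(-c2nnc3nnc(N4CCCCC4)nn23)cc1` gives 30700 nM in this assay, a higher number than that of compound 2 by more than the scatter, so compound 3 is the weaker inhibitor of that pair. Among the three numbers compound 2 holds the second highest value, close to compound 1 and well separated from compound 3.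

Compound 4 `O=[N+]([O-])c1ccc(-c2nnc3nnc(N4CCCC4)n3n2)cc1` has not yet been measured in this assay. It differs from compound 2 in one place: nitro in place of fluoro on an aromatic carbon. Among the measured compounds shown here, no pair of measured compounds separated by a single change exists in this set, so the data offer nothing with which to scale the step. The expected step is therefore a small one, a 1.3-fold lower number from compound 2 to compound 4 (0.11 log units; within the scatter), not clearly beyond the scatter in either direction. Compound 4 is expected to give about 3500 nM in this assay, with a range from 1000 nM to 12000 nM.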

Compound 4, half-maximal inhibitory concentration: > 100000 nM
Compound 4: only a limit was reported; the forecaster's own chance of this, stated with the estimate: 5%; at least 28-fold (1.45 log units) between middle value and limit.
By their numbers in this assay, from the lowest: compounds 1 and 2 (each within the scatter of the next); then compound 3. At a limit, above all of these: compound 4.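

Nitro in place of fluoro on an aromatic carbon, para to a large group, gives an at least 21-fold higher number from compound 2 to compound 4 (1.34 log units; beyond the scatter) in this assay, so the group at this position can decide whether the series shows any measurable effect in this read-out. Compound 4 has a limit and not a number, > 100000 nM, so the step has a known minimum but no known full size: the limit of > 100000 nM in this assay, at which 1 of the 4 values shown sits. The earlier compounds included no pair differing in one place, so this is the first single change that can be read in the series, and the data shown do not give a reason for its size.

One step cannot show whether the result is specific to nitro or extends to other replacements for fluoro, so an amine, a nitrile, a carboxylic acid or plain hydrogen on the same aromatic carbon would be the informative comparisons. On these data alone, it also remains open whether the same exchange would give a step of similar size on the core of compound 3 or with the substitution pattern of compound 1.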